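This account rests on a few compounds, and the source may have more. Where it says the series, first, only, none or still open, it means among the compounds named here.

In an assay on CHO cells for antagonist activity at transient receptor potential cation channel subfamily V member 1 (Homo sapiens), read by FLIPR (a higher number here means a weaker inhibitor, a lower number a stronger inhibitor), compound 2 `CC(C(=O)NCc1ccc(C(F)(F)F)cc1N1CCCC1)c1ccc(NS(C)(=O)=O)c(F)c1` gives 2.3 nM. Its number is the highest of the three recorded so far, yet both of the others lie within the scatter of it: compound 3 `CC(C)CCSc1cc(C(F)(F)F)ccc1CNC(=O)C(C)c1ccc(NS(C)(=O)=O)c(F)c1` gives 1.4 nM, and compound 1 `CCCCN(C)c1cc(C(F)(F)F)ccc1CNC(=O)C(C)c1ccc(NS(C)(=O)=O)c(F)c1` gives 1.2 nM. The steps among these three are all small: a 1.9-fold higher number from compound 1 to compound 2 (0.28 log units; within the scatter), a 1.2-fold higher number from compound 1 to compound 3 (0.07 log units; within the scatter), and a 1.6-fold lower number from compound 2 to compound 3 (0.22 log units; within the scatter).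

Compound 4 `CC(C(=O)NCc1ccc(C(F)(F)F)cc1SC1CCCCC1)c1ccc(NS(C)(=O)=O)c(F)c1` has not yet been measured in this assay. It differs from compound 2 in one place: cyclohexylsulfanyl in place of pyrrolidin-1-yl on an aromatic carbon. Among the measured compounds shown here, the step that bears most directly on it is the one from compound 2 to compound 3, in which isopentylsulfanyl replaced the same pyrrolidin-1-yl on the same aromatic carbon and the number hardly moved. The step from compound 1 to compound 3 likewise shows isopentylsulfanyl giving about the same number as butyl(methyl)amino. Three different groups on this aromatic carbon have therefore given numbers within the scatter of one another, and a fourth is expected to do the same. For compound 4 a step of a 1.4-fold lower number from compound 2 to compound 4 (0.13 log units; within the scatter) is expected, which amounts to no change beyond the scatter. Compound 4 is thus estimated at 1.7 nM, with a range from 0.6 nM to 5 nM.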

Compound 4, inhibition constant: 0.5 nM
Beside the measured number, compound 4's estimate is 3.4-fold (0.53 log units) above it, outside the stated range (below it).
By their numbers in this assay, from the lowest: compound 4; then compounds 1, 3 and 2 (each within the scatter of the next).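

In this assay, among the compounds shown here, the three earlier groups on this aromatic carbon had left the number within the scatter, so the position looked tolerant of quite different groups; cyclohexylsulfanyl is the first change here to move it beyond the scatter, both against the pyrrolidin-1-yl group (a 4.6-fold lower number from compound 2 to compound 4 (0.66 log units; beyond the scatter)) and against the butyl(methyl)amino group (a 2.4-fold lower number from compound 1 to compound 4 (0.38 log units; beyond the scatter)). The sulfur alone does not go with the lower number, for compound 3 carries a sulfur too and stays within the scatter of compound 1 and compound 2, while changing only isopentyl to cyclohexyl on that sulfur gives a step of its own (a 2.8-fold lower number from compound 3 to compound 4 (0.45 log units; beyond the scatter)), so what is attached to the sulfur matters at this position. Nothing measured here bears on why the cyclohexyl ring gives the lower number.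

The compounds shown leave open whether the cyclohexyl ring gives a similar step when joined through a nitrogen or an oxygen, as in cyclohexylamino or cyclohexyloxy. Also open, going by these compounds, is whether another ring on the sulfur, such as cyclopentyl or phenyl, would keep the number this low.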